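The source may hold more compounds than are shown below. What is called first, only, known or untested is meant among the compounds shown, and "the series" means these compounds.

Compound 1, `COC(=O)c1nc(C)n(-c2ccc(OC)cc2)n1`: in a functional assay on NPC-TW01 cells (Homo sapiens) for inhibition, read by MTT assay, with a stated time of 72 h (a higher number here means a weaker inhibitor of growth, a lower number a stronger inhibitor of growth), compound 1 gives 9920 nM.
Compound 2, `COC(=O)c1nc(C)n(-c2ccc(Cl)cc2)n1`: in this assay compound 2 gives 17500 nM.
Compound 3, `COC(=O)c1nc(C(C)C)n(-c2ccc(F)cc2)n1`: in this assay compound 3 gives only a limit of the assay, > 100000 nM.

Compounds 1 and 2 share a methyl on the core and differ only in the group on the aryl ring: a 1.8-fold higher number from compound 1 to compound 2 (0.25 log units; within the scatter). Compound 3 carries an isopropyl on the core and a fluoro on the aryl ring, and its result is a limit of the assay, (the limit of > 100000 nM in this assay, at which 1 of the 3 values shown sits), so where it truly stands is not known beyond that limit.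

Compound 4, `COC(=O)c1nc(C2CCCC2)n(-c2ccc(F)cc2)n1`, differs from compound 3 in one place: cyclopentyl in place of isopropyl on an aromatic carbon. Going by the values given here, the only measured step, from compound 1 to compound 2, concerns the aryl ring and not the alkyl on the core, so no measured step bears on this change. Starting from a limit, neither the size nor the direction of the step in this assay can be read from the data. Compound 4 is therefore expected to land near the limit as well, at an estimated 100000 nM, within an expected range of 30000 nM to 300000 nM. The expected step is then a number no higher from compound 3 to compound 4 (the limit leaves the size open).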

Compound 4, concentration for 50% growth inhibition: 10400 nM
For compound 4 the middle estimate is 9.6-fold (0.98 log units) above the measured one; measured number outside the range, below it.
By their numbers in this assay, from the lowest: compounds 1, 4 and 2 (each within the scatter of the next). At a limit, above all of these: compound 3.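

In this assay, the group on the aromatic carbon between two ring nitrogen atoms can change the result, with cyclopentyl in place of isopropyl giving an at least 9.6-fold lower number from compound 3 to compound 4 (0.98 log units; beyond the scatter). This is the first change shown at this position, and it lies beyond the scatter, whereas the only earlier step concerned the aryl ring and lay within it. The step's true size stays open, as compound 3 sits at a limit of the assay: the limit of > 100000 nM in this assay, at which 1 of the 4 values shown sits.

Whether the ring of cyclopentyl or simply its five carbons account for the change remains open, and a straight pentyl chain or a cyclohexyl ring at this position would help separate the two. As far as these compounds go, how a group carrying an amine would behave here, with the fluoro kept on the aryl ring, is also open.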